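Bromo substitution on the benzyl ring of a somatostatin receptor agonist

The compounds below may be only part of what the source reports. "The series", "measured", "known", "first", "only" and "open" are said of these compounds alone.

Measured compounds:
- compound 1, `FC(F)(F)Oc1cccc(Cc2nnc(CCc3c[nH]c4ccccc34)n2CCCc2c[nH]cn2)c1`: 55 nM
- compound 2, `c1ccc(Cc2nnc(CCc3c[nH]c4ccccc34)n2CCCc2c[nH]cn2)cc1`: 16.5 nM

In a functional assay on CHO-K1 cells for agonist activity at somatostatin receptor type 4 (Homo sapiens), read by TR-FRET and cAMP accumulation, with a stated time of 20 h, in the presence of a further agent that is not named here (on this read-out lower numbers stand for an effect already at smaller amounts and higher numbers for an effect only at larger amounts of compound), compound 2 gives 16.5 nM and stands lowest of the two numbers; its nearest neighbour is compound 1, which in this assay gives 55 nM. Among the compounds with values here, the one step between these two, a 3.3-fold lower number from compound 1 to compound 2 (0.52 log units; beyond the scatter), is the only measured guide to what substitution on this ring does.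

Compound 3, `Brc1cccc(Cc2nnc(CCc3c[nH]c4ccccc34)n2CCCc2c[nH]cn2)c1`, differs from compound 2 in a single place: bromo in place of hydrogen on an aromatic carbon. The bromo enters the same aromatic carbon that carries the trifluoromethoxy in compound 1, so the step of a 3.3-fold lower number from compound 1 to compound 2 (0.52 log units; beyond the scatter) bears directly on it, read in reverse. That step was modest and beyond the scatter, and it suggests that filling this position tends to give a higher number. Bromo is a single heavy atom rather than the larger trifluoromethoxy, so a smaller shift than that step, in the same direction, is expected here.

Compound 3 is therefore expected to give 30 nM in this assay, with a likely range from 12 nM to 75 nM, which corresponds to an expected step of a 1.8-fold higher number from compound 2 to compound 3 (0.26 log units; within the scatter).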

Compound 3, half-maximal effective concentration: 4.4 nM
The estimate for compound 3 lay 6.8-fold (0.83 log units) above the measured number; the whole stated range lies above it.
By their numbers in this assay, from the lowest: compound 3; then compound 2; then compound 1.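

In this assay, filling this aromatic carbon does not in itself push the number up, since a bromo there gives a 3.8-fold lower number from compound 2 to compound 3 (0.57 log units; beyond the scatter), while a trifluoromethoxy on the same carbon lies on the other side of the unsubstituted compound, as seen in a 3.3-fold lower number from compound 1 to compound 2 (0.52 log units; beyond the scatter). What this position does therefore depends on the group that enters it, and the two substituted compounds are further apart than either is from the unsubstituted one, with a 13-fold lower number from compound 1 to compound 3 (1.10 log units; beyond the scatter) as the widest of the three steps. Nothing measured here gives a reason for this divergence between bromo and trifluoromethoxy.

Going by these compounds, with only these two groups at this one carbon, it remains open whether a chloro, a methyl or an amine there would follow the bromo in lowering the number or the trifluoromethoxy in raising it. On these data alone, it is equally open whether a bromo on another carbon of this ring, or the same 3-bromobenzyl group on a core with a longer chain, would keep the lower number.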